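Replacing methoxy with fluoro on compound 3

The source may report more compounds than this note shows. Statements on the series, on what has been measured and on what is new or still open speak of the compounds shown alone.

Values so far in an ADME assay on HEK-293T cells (Homo sapiens) for inhibition, read by CCK-8 assay, with a stated time of 48 h, tested at 20 uM (a lower number here means less inhibition of growth, a higher number more inhibition of growth at the concentration tested), are these:
- Compound 1 `COc1ccc(S(=O)(=O)Oc2ccccc2/C=C(\C#N)C(=O)Nc2nnc(-c3cccs3)s2)cc1` gives 40%
- Compound 2 `Cc1ccc(S(=O)(=O)Oc2ccccc2/C=C(\C#N)C(=O)Nc2nnc(Cc3ccc(F)cc3)s2)cc1` gives 16%
- Compound 3 `COc1ccc(S(=O)(=O)Oc2ccccc2/C=C(\C#N)C(=O)Nc2nnc(Cc3ccc(F)cc3)s2)cc1` gives 20%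

Compound 3 at 20% lies within the scatter of compound 2 at 16% and clearly under compound 1 at 40% on this scale. The next compound is compound 4 `N#C/C(=C\c1ccccc1OS(=O)(=O)c1ccc(F)cc1)C(=O)Nc1nnc(Cc2ccc(F)cc2)s1` which departs from compound 3 by fluoro in place of methoxy on an aromatic carbon and this is fluoro in place of methoxy on an aromatic carbon, para to a large group.

For the measured compounds named here, two measured steps bear on this change. The closer one, a number 4 percentage points higher from compound 2 to compound 3 (within the scatter) for methoxy in place of methyl on an aromatic carbon, touches the same group. The other, a number 20 percentage points lower from compound 1 to compound 3 (beyond the scatter) for 4-fluorobenzyl in place of thiophen-2-yl on an aromatic carbon, lies elsewhere in the structure. Compound 4 keeps the 4-fluorobenzyl group of compound 3. Going by the values given here, no measured compound carries fluoro at the changed carbon, so the evidence is indirect.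

Starting from compound 3 at 20% and its small step from compound 2, no change beyond the scatter is expected in this assay here. The estimated step is no change at the digits printed from compound 3 to compound 4 (within the scatter) for this exchange. For compound 4 the estimate is 20% with an expected range from 9% to 33% in this measurement.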

Compound 4, percent growth inhibition at one concentration: "not toxic" (no number reported)
No number was reported for compound 4, and the estimate cannot be compared.
By their numbers in this assay, from the lowest: compounds 2 and 3 (each within the scatter of the next); then compound 1.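

In this assay, for the compounds shown here, compound 4 is reported in words only, without a number, so no step from compound 3 to compound 4 can be read. The compounds shown leave open how fluoro in place of methoxy alters growth inhibition on a numerical scale. No measured evidence here accounts for the result.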